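This account rests on a few compounds, and the source may have more. Where it says the series, first, only, none or still open, it means among the compounds named here.

Compound 1 `COc1ccc(-c2cc(C(=O)/C=C/c3ccccc3)nc3cc(-c4ccccc4)nn23)cc1OC`: 15600 nM
Compound 2 `COc1cc(-c2cc(C(=O)/C=C/c3ccccc3)nc3cc(-c4ccccc4)nn23)cc(OC)c1OC`: 16300 nM
Compound 3 `COc1ccc(-c2cc(/C=C/C(=O)c3ccc(C)c(C)c3)nc3cc(-c4ccccc4)nn23)cc1OC`: 12100 nM

In a functional assay on DU-145 cells (Homo sapiens) for antiproliferative activity, read by MTT assay, with a stated time of 24 h (on this read-out lower numbers stand for stronger inhibition and higher numbers for weaker inhibition), compound 1 gives 15600 nM, the second highest of the three numbers. Its nearest neighbour is compound 2, reached by a 1.0-fold higher number from compound 1 to compound 2 (0.02 log units; within the scatter); the furthest is compound 3, reached by a 1.3-fold lower number from compound 1 to compound 3 (0.11 log units; within the scatter). Both steps lie within the scatter, so the three measured compounds cannot be told apart on this read-out.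

Compound 4 `COc1ccc(-c2cc(C(=O)/C=C/c3cc(OC)c(OC)c(OC)c3)nc3cc(-c4ccccc4)nn23)cc1OC` has not been measured. It differs from compound 1 in one place: 3,4,5-trimethoxyphenyl in place of phenyl on a double-bonded chain carbon bound to a double-bonded chain carbon. Going by the values given here, no measured step repeats this change. The closest comparison is the added methoxy on the aryl bound to the core, a 1.0-fold higher number from compound 1 to compound 2 (0.02 log units; within the scatter), which left the number unchanged; the exchange of the chain in the step from compound 1 to compound 3 was likewise within the scatter. With only these small steps to go on, the step of a 1.1-fold lower number from compound 1 to compound 4 (0.05 log units; within the scatter) is expected to fall within the scatter, in no clear direction. Compound 4 is therefore estimated at 14000 nM, within a range of 6500 nM to 30000 nM in this assay.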

Compound 4, half-maximal inhibitory concentration: 14700 nM
Beside the measured number, compound 4's estimate is 1.1-fold (0.02 log units) below it, within the range that was stated.
By their numbers in this assay, from the lowest: compounds 3, 4, 1 and 2 (each within the scatter of the next).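

Compound 2 kept the phenyl on the chain and compound 3 exchanged the whole chain, so compound 4 is the one that tests this aryl alone. In this assay, the step of a 1.1-fold lower number from compound 1 to compound 4 (0.03 log units; within the scatter) shows that 3,4,5-trimethoxyphenyl, with 12 heavy atoms and 3 hydrogen-bond acceptors, can replace phenyl, with 6 heavy atoms and none, without a shift beyond the scatter, much as the added methoxy on the aryl bound to the core did in the step of a 1.0-fold higher number from compound 1 to compound 2 (0.02 log units; within the scatter). No evidence is available that bears on this result.

From the compounds shown here alone, it remains open whether an amine or a carboxylic acid on this aryl would move the number beyond the scatter. Going by these compounds, whether a single methoxy or a halogen such as chlorine at this place would behave like the three methoxy groups also remains open.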